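Extending the side chain of compound 3 by one carbon

A few compounds are considered here, and "the series" means these few. Any claim that something is new, unique, unknown or untested is made for them only; others in the source may bear on it.

Compound 1 `C(=N/c1ccccc1)\c1cc(-c2ccccc2)no1` gives > 100000 nM in a functional assay on MDA-MB-231 cells (Homo sapiens) for inhibition, read by MTT assay, with a stated time of 24 h (a higher number here means a weaker inhibitor, a lower number a stronger inhibitor), which is a limit of the assay and not a number.
Compound 2 `Cc1ccc(-c2cc(/C=N/c3ccccc3)on2)cc1` gives 29400 nM in this assay.
Compound 3 `CCc1cc2ccccc2nc1-c1cc(-c2ccccc2)no1` gives > 100000 nM in this assay, again a limit of the assay.

Compound 3 therefore stands only at a limit; it shares that position with one other value, as the limit of > 100000 nM in this assay, at which 2 of the 3 values shown sit, records, and the numbers shown place it no further than that. Within the data shown here, the single measured step, an at least 3.4-fold lower number from compound 1 to compound 2 (0.53 log units; beyond the scatter), concerns a methyl on an aromatic carbon and is the only change of size seen here. Compound 4 `CCCc1cc2ccccc2nc1-c1cc(-c2ccccc2)no1` differs from compound 3 by methyl in place of hydrogen on a saturated chain carbon, two bonds along the chain from an aromatic carbon. Among the measured compounds shown here, no measured step touches a saturated chain carbon, so the one step recorded does not bear directly on this change. With compound 3 at a limit, compound 4 is expected to remain at a limit as well, and the step that the limit leaves unreadable from compound 3 to compound 4 is an estimate with no measured support. Compound 4 is estimated at 150000 nM, within a range from 30000 nM to 600000 nM.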

Compound 4, half-maximal inhibitory concentration: 47200 nM
Compound 4: middle estimate off by 3.2-fold (0.50 log units), on the high side, within the range that was stated.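

In this assay, the change from ethyl to propyl gives the first readable effect at a saturated chain carbon, two bonds along the chain from an aromatic carbon: an at least 2.1-fold lower number from compound 3 to compound 4 (0.32 log units; beyond the scatter). Together with the step on an aromatic carbon, this gives a second place on these compounds where methyl in place of hydrogen lowers the number, and here the change brings the shared core of compound 3 off the limit to a measured value. The step gives only a lower bound on the size of the change, because its starting point is a limit of the assay: the limit of > 100000 nM in this assay, at which 2 of the 4 values shown sit.

The compounds shown leave open whether a longer chain, such as butyl, would lower the number further or raise it again. They also leave open how an amine or a carboxylic acid in place of the propyl group would compare with compound 4.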